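A Mirror-Image Pair and a New Aryl Group

The source may hold more compounds than are shown below. What is called first, only, known or untested is meant among the compounds shown, and "the series" means these compounds.

- compound 1 `O=C1C[C@@H]2O[C@@H](Cc3ccccc3)[C@@H](O)[C@@H]2O1`: 170 nM
- compound 2 `O=C1C[C@H]2O[C@H](Cc3ccccc3)[C@H](O)[C@H]2O1`: 43800 nM

In a functional assay on HL-60 cells (Homo sapiens) for antiproliferative activity, read by MTT assay, with a stated time of 72 h (a higher number here means a weaker inhibitor, a lower number a stronger inhibitor), compound 1 gives 170 nM and compound 2 gives 43800 nM, so compound 2 holds the higher of the two numbers and is the weaker inhibitor. The gap between them, a 260-fold higher number from compound 1 to compound 2 (2.41 log units; beyond the scatter), is due to the fact that compounds 1 and 2 differ only in the configuration as drawn.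

Compound 3 `Cc1ccccc1[C@H](c1ccccc1)[C@H]1O[C@@H]2CC(=O)O[C@@H]2[C@H]1O` keeps the configuration of compound 2 at the shared core and changes in one place: 2-methylphenyl in place of hydrogen on a saturated chain carbon bound to an aromatic carbon and a saturated ring carbon. Thus 2-methylphenyl takes the place of hydrogen on a saturated chain carbon bound to an aromatic carbon and a saturated ring carbon.

For the measured compounds named here, the one measured step is a change of configuration, not of substituent, so it gives no direct size for this change. It shows only how far numbers can move in this small series. With compound 2 at 43800 nM, a modest move toward lower numbers seems the likelier outcome, though with wide uncertainty, and a move in the other direction is not ruled out. The expected change is a 3.7-fold lower number from compound 2 to compound 3 (0.56 log units; beyond the scatter). The estimate for compound 3 is 12000 nM, with an expected range from 1500 nM to 70000 nM.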

Compound 3, half-maximal inhibitory concentration: 11700 nM
For compound 3 the middle estimate is 1.0-fold (0.01 log units) above the measured one, and the stated range covers the measured number.
By their numbers in this assay, from the lowest: compound 1; then compound 3; then compound 2.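

In this assay, the saturated chain carbon bound to an aromatic carbon and a saturated ring carbon accepts 2-methylphenyl in place of hydrogen, and the result is a 3.7-fold lower number from compound 2 to compound 3 (0.57 log units; beyond the scatter). The earlier compounds shown here showed only what a change of configuration does; here a substituent changes while the configuration of compound 2 stays in place, and this modest step is much smaller than the mirror-image step, a 260-fold higher number from compound 1 to compound 2 (2.41 log units; beyond the scatter). Nothing given here explains why this added group lowers the number.

The compounds shown leave open whether the same replacement would move the number in the same direction and by a similar amount on the configuration of compound 1, and whether the step depends on the methyl group of 2-methylphenyl or on the added aromatic ring alone. They also leave open how this carbon would respond to a second unsubstituted phenyl, which would separate those two parts, or to a different kind of group such as an amine or a carboxylic acid.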